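The compounds below may be only part of what the source reports. "The series", "measured", "known", "first", "only" and "open" are said of these compounds alone.

Values in an ADME assay on NIH3T3 cells (Mus musculus) for cytotoxicity, read by MTT assay, with a stated time of 24 h; on this read-out lower numbers stand for stronger inhibition and higher numbers for weaker inhibition:
- Compound 1 `N#Cc1ccc(-c2cs/c(=N/NC(=O)CSc3ncccn3)n2-c2ccccc2)cc1`: < 3.9 ug/mL
- Compound 2 `Cn1nnnc1SCC(=O)N/N=c1/scc(-c2ccc(Cl)cc2)n1-c1ccccc1`: 40 ug/mL

Compound 1 gives only a limit, < 3.9 ug/mL. Within the data shown here, compound 2, at 40 ug/mL, therefore holds the only actual number so far.

Compound 3 `O=C(CSc1ncccn1)N/N=c1/scc(-c2ccc(Cl)cc2)n1-c1ccccc1` puts pyrimidin-2-yl in place of 1-methyl-1H-tetrazol-5-yl on a sulfur of compound 2: pyrimidin-2-yl in place of 1-methyl-1H-tetrazol-5-yl on a sulfur. No measured step sizes this change. Compound 1 also carries pyrimidin-2-yl and sits at the limit of < 3.9 ug/mL. On that slim basis, stronger inhibition beyond the scatter is expected in this assay. The expected change is a 3.3-fold lower number from compound 2 to compound 3 (0.52 log units; beyond the scatter). For compound 3 the estimate is 12 ug/mL, with an expected range of 3 ug/mL to 35 ug/mL.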

Compound 3, half-maximal inhibitory concentration: 397 ug/mL
For compound 3 the middle estimate is 33-fold (1.52 log units) below the measured one, and the stated range ends below it.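

In this assay pyrimidin-2-yl in place of 1-methyl-1H-tetrazol-5-yl on a sulfur gives a 9.9-fold higher number from compound 2 to compound 3 (1.00 log units; beyond the scatter) and so pyrimidin-2-yl alone does not bring strong inhibition. With pyrimidin-2-yl held, chloro in place of cyano on an aromatic carbon gives an at least 100-fold higher number from compound 1 to compound 3 (2.00 log units; beyond the scatter) and the strong inhibition of compound 1 does not carry over to the chloro compound. That step is only a bound, as compound 1 gives a limit: the limit of < 3.9 ug/mL in this assay, at which 1 of the 3 values shown sits.

Open, on these data alone, is whether the two changes add up when cyano is paired with 1-methyl-1H-tetrazol-5-yl. Also open, as far as these compounds go, is how an aminoethyl chain or a pyridin-2-yl group on that sulfur would read.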